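This account rests on a few compounds, and the source may have more. Where it says the series, first, only, none or still open, it means among the compounds named here.

Compound 1 `CC1CCN(C2CCN(S(=O)(=O)c3cn(C)cn3)CC2)CC1` — > 10000 nM
Compound 2 `CC1CCN(C2CCN(S(=O)(=O)c3cccc(-c4ccccc4F)c3)CC2)CC1` — > 5000 nM

In an ADME assay on HCT-116 cells (Homo sapiens) for cytotoxicity, read by CellTiter-Glo, with a stated time of 72 h (a higher number here means a weaker inhibitor, a lower number a stronger inhibitor), compound 1 gives > 10000 nM, which is a limit of the assay and not a number (the limit of > 10000 nM in this assay, at which 1 of the 2 values shown sits). Compound 2 likewise gives > 5000 nM, again a limit and not a number (the limit of > 5000 nM in this assay, at which 1 of the 2 values shown sits). So compound 1 stands only at a limit, and the one further value shown is a limit as well; no step between measured compounds can be read from these two, and nothing in this assay separates them.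

Compound 3 `Cc1nc(Cl)sc1S(=O)(=O)N1CCC(N2CCC(C)CC2)CC1` is the next compound to be measured. It differs from compound 1 in one place: 2-chloro-4-methyl-1,3-thiazol-5-yl in place of 1-methyl-1H-imidazol-4-yl on a sulfonyl sulfur. With both shown values sitting at limits, there is no measured step to lean on. The expected step is a step that the limit leaves unreadable from compound 1 to compound 3, no more than the usual scatter, with a high chance that only a limit is reported again. Compound 3 is therefore expected at about 15000 nM, within a range from 5000 nM to 50000 nM.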

Compound 3, half-maximal inhibitory concentration: > 10000 nM
Compound 3 was reported as a limit; the forecaster's own chance of this, stated with the estimate: 85%; the middle value does not contradict the limit.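

In this assay compound 3 gives > 10000 nM, a limit and not a number. Within the data shown here, compound 1 also stands at a limit, so no step from compound 1 to compound 3 can be read. The compounds shown leave open whether 2-chloro-4-methyl-1,3-thiazol-5-yl and 1-methyl-1H-imidazol-4-yl differ at all in this assay.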